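Swapping a furan for a methylpyridine on the sulfonyl group

A few compounds are considered here, and "the series" means these few. Any claim that something is new, unique, unknown or untested is made for them only; others in the source may bear on it.

Compound 1 `CNCc1cn(S(=O)(=O)c2ccoc2)c(-c2cccnc2F)c1F` was measured in a physicochemical assay for lipophilicity, read by HPLC, at pH 7.4 (on this read-out lower numbers stand for lower lipophilicity and higher numbers for higher lipophilicity), and gave 0.45. Among the three measured compounds, compound 1 stands second highest: compound 2 `CNCc1cn(S(=O)(=O)c2ncccc2C)c(-c2cccnc2F)c1F` gives 0.32, and compound 3 `CNCc1cn(S(=O)(=O)c2cccc(C)n2)c(-c2cccnc2F)c1F` gives 0.71. The step of a number 0.13 log units lower from compound 1 to compound 2 (within the scatter) and the step of a number 0.26 log units higher from compound 1 to compound 3 (within the scatter) both stay within the scatter, while the step of a number 0.39 log units higher from compound 2 to compound 3 (beyond the scatter) is modest but beyond it.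

Compound 4 `CNCc1cn(S(=O)(=O)c2cncc(C)c2)c(-c2cccnc2F)c1F` has not yet been measured. It differs from compound 1 in one place: 5-methylpyridin-3-yl in place of furan-3-yl on a sulfonyl sulfur. The two measured steps that bear on this change are those from compound 1 to compound 2 and from compound 1 to compound 3, where a methyl-bearing pyridine also replaces the furan on the sulfonyl sulfur; one went slightly down and one slightly up, neither beyond the scatter. For compound 4 a step of a number 0.05 log units higher from compound 1 to compound 4 (within the scatter) is therefore expected, which is no more than the scatter allows. Compound 4 is estimated to give 0.5 in this assay, within a range from 0.15 to 0.85.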

Compound 4, distribution coefficient: 0.61
Compound 4: the middle estimate sits 0.11 log units below what was measured, and the stated range covers the measured number.
By their numbers in this assay, from the lowest: compounds 2, 1, 4 and 3 (each within the scatter of the next, the first and the last beyond it).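

In this assay, within the data shown here, 5-methylpyridin-3-yl is the first group on the sulfonyl sulfur in this set joined through the 3-position of a pyridine rather than the 2-position, yet compound 4 lies within the scatter of all three earlier compounds (a number 0.16 log units higher from compound 1 to compound 4 (within the scatter)), (a number 0.10 log units lower from compound 3 to compound 4 (within the scatter)) and (a number 0.29 log units higher from compound 2 to compound 4 (within the scatter)). Among these compounds, the six-membered ring therefore takes the place of the furan with no step beyond the scatter, and the only such step in the set remains the one between the two pyridin-2-yl compounds (a number 0.39 log units higher from compound 2 to compound 3 (beyond the scatter)). Nothing measured here explains where these numbers fall.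

On these data alone, it remains open whether a phenyl ring, or a pyridine carrying an amine or a carboxylic acid, would move the number beyond the scatter from compound 1. What the methyl itself contributes also remains open, as every pyridine shown carries one.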